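Swapping the amide ring in a weakly inhibiting series

This account rests on a few compounds, and the source may have more. Where it says the series, first, only, none or still open, it means among the compounds named here.

Compound 1, `CS(=O)(=O)c1ccc(C(=O)N2CCC(C(=O)N3CCC(c4ccccc4)CC3)CC2)cc1[N+](=O)[O-]`: > 60000 nM
Compound 2, `CS(=O)(=O)c1ccc(C(=O)NCC(=O)N2CCCCC2)cc1[N+](=O)[O-]`: 44000 nM
Compound 3, `CN(CC(=O)N1CCc2ccccc2C1)C(=O)c1ccc(S(C)(=O)=O)c([N+](=O)[O-])c1`: > 60000 nM

These three compounds were tested in an assay on isolated protein for inhibition of thyroid hormone receptor alpha (Homo sapiens), read by fluorescence polarization; on this read-out higher numbers stand for weaker inhibition and lower numbers for stronger inhibition. Among the measured compounds shown here, compound 2 gives 44000 nM, and this is the only actual number in the set. For compound 1 the value > 60000 nM is a limit of the assay, not a number. For compound 3 the value > 60000 nM is likewise a limit. Most of the set therefore lies beyond what the assay can measure: the limit of > 60000 nM in this assay, at which 2 of the 3 values shown sit. For the measured compounds named here, compound 2 thus stands as the one compound for which a number was obtained, with weak inhibition.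

Compound 4, `CN1CCN(C(=O)CNC(=O)c2ccc(S(C)(=O)=O)c([N+](=O)[O-])c2)CC1`, has not been measured. It differs from compound 2 in one place: 4-methylpiperazin-1-yl in place of piperidin-1-yl on a carbonyl carbon. Going by the values given here, no measured pair in the set differs in a similar way, so there is no step to lean on. The nearby compounds all sit at or near the top of the measurable range, and a change of one ring of this kind is expected to move the value little, if at all, beyond the usual scatter in this assay .

Compound 4 is therefore expected to give about 50000 nM, with a range from 20000 nM to 120000 nM. This corresponds to an expected step of a 1.1-fold higher number from compound 2 to compound 4 (0.06 log units; within the scatter), within the scatter, with a fair chance that only a limit is reported.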

Compound 4, half-maximal inhibitory concentration: > 60000 nM
Compound 4 gave a limit, no number; the forecaster's own chance of this, stated with the estimate: 45%; middle value at least 1.2-fold (0.07 log units) away from the limit.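

Among the compounds shown here, this is the only direct comparison at this place, a carbonyl carbon whose other neighbour is a saturated chain carbon. Putting 4-methylpiperazin-1-yl in place of piperidin-1-yl gives an at least 1.3-fold higher number from compound 2 to compound 4 (0.13 log units; that floor lies within the scatter), so this one-ring change offers no sign of stronger inhibition, but the step alone cannot separate a real loss from ordinary scatter. Compound 4 gives > 60000 nM, which is a limit of the assay and not a number, so the true size of the step cannot be stated, and the set now sits even more heavily at the edge of what this assay can read: the limit of > 60000 nM in this assay, at which 3 of the 4 values shown sit.

Piperidin-1-yl, in compound 2, is still the only group at this place with a real number, and a single pair cannot establish a trend. From the compounds shown here alone, it remains open whether a morpholine ring, an open-chain amine such as dimethylamino, or a carboxylic acid on this carbonyl carbon would bring inhibition into the measurable range, and whether changes elsewhere on the shared core would do more than changes to this ring.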